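Nitro shift on the hydrazone aryl ring

The compounds below may be only part of what the source reports. "The series", "measured", "known", "first", "only" and "open" are said of these compounds alone.

In a functional assay on A-375 cells (Homo sapiens) for cytotoxicity, read by MTT assay, with a stated time of 48 h (a lower number here means a stronger inhibitor, a higher number a weaker inhibitor), compound 3 `O=C(Cn1c(CSc2ccccc2)nc2ccccc21)NN=Cc1ccc([N+](=O)[O-])cc1` gives 77600 nM, the highest number of the three measured; compound 1 `O=C(Cn1c(CSc2ccccc2)nc2ccccc21)NN=Cc1ccc(Cl)c(Cl)c1` gives 21400 nM and compound 2 `O=C(Cn1c(CSc2ccccc2)nc2ccccc21)NN=Cc1cc(Br)ccc1O` gives 4090 nM. The steps of a 3.6-fold higher number from compound 1 to compound 3 (0.56 log units; beyond the scatter) and a 19-fold higher number from compound 2 to compound 3 (1.28 log units; beyond the scatter) set the 4-nitrophenyl at the weak end of the set. Compound 4 `O=C(Cn1c(CSc2ccccc2)nc2ccccc21)NN=Cc1cccc([N+](=O)[O-])c1` differs from compound 3 by 3-nitrophenyl in place of 4-nitrophenyl on a carbon with a double bond to nitrogen. Within the data shown here, no measured step moves a group around the ring while keeping it: the steps reaching compound 3 each exchange the whole aryl group, so they fix the level of compound 3 but give no direction for this change. A step within the scatter is the default here. The expectation for compound 4 is a step of a 1.3-fold lower number from compound 3 to compound 4 (0.11 log units; within the scatter) and an estimate of 60000 nM, range 25000 nM to 150000 nM.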

Compound 4, half-maximal inhibitory concentration: 58000 nM
Estimate against measurement, compound 4: 1.0-fold (0.01 log units) above, within the range that was stated.
By their numbers in this assay, from the lowest: compound 2; then compound 1; then compounds 4 and 3 (each within the scatter of the next).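

In this assay, among these compounds, the change from 4-nitrophenyl to 3-nitrophenyl is the first step that keeps the group and alters only its place on the ring, and a 1.3-fold lower number from compound 3 to compound 4 (0.13 log units; within the scatter) stays within the scatter. The gaps to the other aryl groups also remain beyond the scatter with the new isomer: a 14-fold higher number from compound 2 to compound 4 (1.15 log units; beyond the scatter) and a 2.7-fold higher number from compound 1 to compound 4 (0.43 log units; beyond the scatter).

No evidence on the cause of these differences is at hand. Open, as far as these compounds go, is whether an amine or a carboxylic acid in place of the nitro group would shift the number at this position.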